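Working notes: from compound 1 to compound 4

A few compounds are considered here, and "the series" means these few. Any claim that something is new, unique, unknown or untested is made for them only; others in the source may bear on it.

Measured in a functional assay on MCF7 cells (Homo sapiens) for antiproliferative activity, read by MTT assay, with a stated time of 72 h; on this read-out higher numbers stand for weaker inhibition and lower numbers for stronger inhibition:
Compound 1 `O=C(COc1ccc(C(=O)/C=C/c2ccccc2Cl)cc1)N[C@H]1CCOC1=O` gives 17400 nM.
Compound 2 `CCCCCCCCCCSC(=S)N[C@H]1CCOC1=O` gives > 64000 nM, which is a limit of the assay.
Compound 3 `O=C(CNc1cccc(Cl)c1)N[C@H]1CCOC1=O` gives > 64000 nM, which is a limit of the assay.

Compound 1 stands as the only entry with a numerical value in this assay; the other two entries sit at the limit of > 64000 nM in this assay, at which 2 of the 3 values shown sit. Among the measured compounds shown here, no pair of measured compounds differs in a single place, so no measured step is available for comparison.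

Compound 4 `O=C(COc1ccc(C(=O)/C=C/c2cccc([N+](=O)[O-])c2)cc1)N[C@H]1CCOC1=O` differs from compound 1 by 3-nitrophenyl in place of 2-chlorophenyl on a double-bonded chain carbon bound to a double-bonded chain carbon. The change keeps the shared core of compound 1 and exchanges one aryl group on the double-bonded chain for another. With no measured step of this kind in the set, the expectation is a step of modest size, within the scatter or only slightly beyond it, leaning toward stronger inhibition.

For compound 4 the expected value in this assay is estimated at 12000 nM, with a range from 4000 nM to 40000 nM. This estimate corresponds to an expected step of a 1.5-fold lower number from compound 1 to compound 4 (0.16 log units; within the scatter), not clearly beyond the scatter.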

Compound 4, half-maximal inhibitory concentration: > 64000 nM
Compound 4 was reported as a limit; the forecaster's own chance of this, stated with the estimate: 15%; middle value at least 5.3-fold (0.72 log units) away from the limit.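

In this assay, 3-nitrophenyl in place of 2-chlorophenyl on a double-bonded chain carbon bound to a double-bonded chain carbon gives an at least 3.6-fold higher number from compound 1 to compound 4 (0.56 log units; beyond the scatter). Compound 4 gives > 64000 nM, which is a limit of the assay. This is the first measured step in the series: the aryl group at this place is not a free exchange, the shared core of compound 1 alone does not keep a measurable value, and compound 1 remains the only entry with a number: the limit of > 64000 nM in this assay, at which 3 of the 4 values shown sit.

The exchange alters both the ring substituent and where it sits, so the nitro group and its placement cannot be separated here. On these data alone, how a plain phenyl or an aminophenyl at this place would read in this assay remains open.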